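A few compounds are considered here, and "the series" means these few. Any claim that something is new, unique, unknown or untested is made for them only; others in the source may bear on it.

Of the compounds shown here, two with a shared core have been tested in a functional assay on the whole organism (strain Swiss) for inhibition, with Mus musculus as the target, with a stated time of 30 min, at a dose of 5 mg/kg by the intraperitoneal route; a lower number here means a weaker effect, a higher number a stronger effect of the compound at the dose given. Compound 1 `O=C1COCCN1c1ccc(Nc2nc(Cl)nc(N3CCCC3)n2)cc1` gives 87% in this assay. Compound 2 `O=C1COCCN1c1ccc(Nc2nc(Cl)nc(NC3CCCCC3)n2)cc1` gives 56%, and its value stands lowest of the two measured numbers. Going by the values given here, the one measured step, a number 31 percentage points lower from compound 1 to compound 2 (beyond the scatter), replaced pyrrolidin-1-yl with cyclohexylamino on an aromatic carbon.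

Compound 3 `O=C1COCCN1c1ccc(Nc2nc(Cl)nc(Nc3ccccc3)n2)cc1` has not been measured. It differs from compound 2 by phenyl in place of cyclohexyl on a nitrogen on an aromatic ring. Among the compounds with values here, no measured step exchanges a saturated ring for an aromatic one on this nitrogen, so the single known step gives no direct guide to the direction or size of the change. The expected step of a number 1 percentage points lower from compound 2 to compound 3 (within the scatter) is therefore taken as none beyond the scatter. Compound 3 is thus estimated at 55%, within a wide range from 25% to 85% in this assay.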

Compound 3, a percentage reported as inhibition, in the whole organism at one dose (the size of the read-out at that dose, not a potency): 76%
Estimate against measurement, compound 3: 21 percentage points below; the measured number falls inside the stated range.
By their numbers in this assay, from the lowest: compound 2; then compound 3; then compound 1.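

Cyclohexyl and phenyl match in the heavy atoms and hydrogen-bond groups counted for them, yet exchanging the non-aromatic ring for the aromatic one on this nitrogen changes the result in this assay: the change is a number 20 percentage points higher from compound 2 to compound 3 (beyond the scatter). The anilino group still does not fully match pyrrolidin-1-yl on the aromatic carbon, with a number 11 percentage points lower from compound 1 to compound 3 (beyond the scatter). The size of the fall on leaving pyrrolidin-1-yl therefore depends on the ring carried by the nitrogen, at least across these compounds.

Nothing shown explains why the aromatic ring gives the higher number. On these data alone, it remains open whether a phenyl ring carrying a methoxy group or a chlorine atom, or an open chain such as butylamino in place of anilino, would keep, raise or lower the read-out.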